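A few compounds are considered here, and "the series" means these few. Any claim that something is new, unique, unknown or untested is made for them only; others in the source may bear on it.

Within the data shown here, the three compounds measured so far share one core. Compound 1 `CC(C)(Oc1ccccc1)C1OCC(C/C=C\CCC(=O)O)C(c2cccnc2)O1` gives 52 nM in an assay for inhibition of Thromboxane-A synthase (Homo sapiens), using microsomes; a lower number here means a stronger inhibitor, a higher number a weaker inhibitor. Compound 2 `Cc1ccc(OC(C)(C)C2OCC(C/C=C\CCC(=O)O)C(c3cccnc3)O2)cc1` gives 360 nM in this assay, and compound 3 `CC(C)(Sc1ccccc1)C1OCC(C/C=C\CCC(=O)O)C(c2cccnc2)O1` gives 40 nM. Compound 3 thus shows the lowest of the three numbers, though its gap to compound 1 lies within the scatter, so no order between those two can be claimed. The step from compound 2 to compound 3 was a 9.0-fold lower number from compound 2 to compound 3 (0.95 log units; beyond the scatter).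

Compound 4 `Cc1ccc(SC(C)(C)C2OCC(C/C=C\CCC(=O)O)C(c3cccnc3)O2)c([N+](=O)[O-])c1` differs from compound 3 by 4-methyl-2-nitrophenyl in place of phenyl on a sulfur. Among the measured compounds shown here, no measured step places a nitro group on this ring, but a methyl on an aromatic carbon was tested in the phenoxy series, where the step was a 6.9-fold higher number from compound 1 to compound 2 (0.84 log units; beyond the scatter). That step, together with the unmeasured nitro group, makes the author expect a higher number for compound 4, with an estimated step of a 5.0-fold higher number from compound 3 to compound 4 (0.70 log units; beyond the scatter). Compound 4 is therefore estimated at 200 nM in this assay, with a range from 60 nM to 800 nM.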

Compound 4, half-maximal inhibitory concentration: 30 nM
Beside the measured number, compound 4's estimate is 6.7-fold (0.82 log units) above it; measured number below the stated range.
By their numbers in this assay, from the lowest: compounds 4, 3 and 1 (each within the scatter of the next); then compound 2.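

On the sulfur, 4-methyl-2-nitrophenyl in place of phenyl leaves the number in this assay within the scatter (a 1.3-fold lower number from compound 3 to compound 4 (0.12 log units; within the scatter)), so this position accepts the substituted ring with no change that can be claimed. Compound 4 also stays within the scatter of the unsubstituted phenoxy compound (a 1.7-fold lower number from compound 1 to compound 4 (0.24 log units; within the scatter)) yet lies far from the 4-methylphenoxy compound (a 12-fold lower number from compound 2 to compound 4 (1.08 log units; beyond the scatter)), so the rise seen with the methyl in the phenoxy series does not appear here, where the methyl comes together with a nitro group. Nothing measured here accounts for this result.

The compounds shown leave open what the methyl and the nitro group each contribute on the sulfur-linked ring. They also leave open whether an amine in place of the nitro group would keep the number in this assay where it stands.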